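A Cyano Swap on the Aromatic Ring

A few compounds are considered here, and "the series" means these few. Any claim that something is new, unique, unknown or untested is made for them only; others in the source may bear on it.

In a functional assay on HeLa cells (Homo sapiens) for antiproliferative activity, read by MTT assay, with a stated time of 72 h (on this read-out lower numbers stand for stronger inhibition and higher numbers for weaker inhibition), compound 2 (`C=CC(=O)Nc1cccc(Oc2nc(Nc3cccc(OC)c3)nc3c2CSCC3)c1`) gives 28900 nM as its reading, while compound 1 (`C=CC(=O)Nc1cccc(Oc2nc(Nc3ccn(C)n3)nc3c2CSCC3)c1`) gives 25800 nM as its own. Going by the values given here, these are the only two readings so far, and compound 2 stands level with compound 1 within the scatter. Compound 3 (`C=CC(=O)Nc1cccc(Oc2nc(Nc3cccc(C#N)c3)nc3c2CSCC3)c1`) has cyano in place of methoxy on an aromatic carbon and otherwise matches compound 2. Among the compounds with values here, no measured step covers this swap directly. The nearest evidence is a 1.1-fold higher number from compound 1 to compound 2 (0.05 log units; within the scatter) for a change of the whole group on a nitrogen, so no step beyond the scatter is expected in this assay here. The expected change is a 1.1-fold lower number from compound 2 to compound 3 (0.05 log units; within the scatter) for this swap. Compound 3 is estimated at 26000 nM with an expected range from 12000 nM to 50000 nM for repeat measurements.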

Compound 3, half-maximal inhibitory concentration: 34900 nM
Compound 3: the middle estimate sits 1.3-fold (0.13 log units) below what was measured; low and high end bracket the measured number.
By their numbers in this assay, from the lowest: compounds 1, 2 and 3 (each within the scatter of the next).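

In this assay the swap of methoxy for cyano on the six-membered aromatic ring gives a 1.2-fold higher number from compound 2 to compound 3 (0.08 log units; within the scatter) and so leaves the reading unmoved, which shows that this position tolerates two quite different small groups with the same outcome. Changing the whole group on the nitrogen from 1-methyl-1H-pyrazol-3-yl to 3-cyanophenyl gives a 1.4-fold higher number from compound 1 to compound 3 (0.13 log units; within the scatter) and adds a third pair that reads alike. No measurement at hand bears on what lies behind these readings.

All three compounds lie within the scatter of one another, so they do not show whether any group at this ring carbon can move the number at all. On these data alone, whether an amine, a carboxylic acid or a chlorine atom there would shift the reading beyond the scatter remains open.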